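The source may hold more compounds than are shown below. What is called first, only, known or untested is meant among the compounds shown, and "the series" means these compounds.

Compounds measured so far:
Compound 1, `CCCCNC(=O)N1CC1C#N`, gives 14000 nM in a functional assay on WiDr cells (Homo sapiens) for inhibition; a higher number here means a weaker inhibitor, a lower number a stronger inhibitor.
Compound 2, `CCNC(=O)N1CC1C#N`, gives 4000 nM in this assay.

Within the data shown here, compound 2 stands at the lower of the two numbers; its only neighbour is compound 1, and the single measured step, a 3.5-fold lower number from compound 1 to compound 2 (0.54 log units; beyond the scatter), separates them.

Compound 3, `CNC(=O)N1CC1C#N`, differs from compound 2 by hydrogen in place of methyl on a saturated chain carbon bound to an amide-type nitrogen. Cut one bond further out, the same change reads ethyl to methyl, so it shortens the chain on the amide-type nitrogen by one carbon. Among the measured compounds shown here, the only step that bears on it is a 3.5-fold lower number from compound 1 to compound 2 (0.54 log units; beyond the scatter), which took two carbons off the same chain and gave a modest drop. Taking off one more carbon is expected to give a smaller step in the same direction, or none beyond the scatter; the step expected is a 1.6-fold lower number from compound 2 to compound 3 (0.20 log units; within the scatter). Compound 3 is therefore estimated at 2500 nM, with a range from 800 nM to 8000 nM.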

Compound 3, half-maximal inhibitory concentration: 21000 nM
For compound 3 the middle estimate is 8.4-fold (0.92 log units) below the measured one, outside the stated range (above it).
By their numbers in this assay, from the lowest: compound 2; then compounds 1 and 3 (each within the scatter of the next).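

Removing one carbon from the chain on the amide-type nitrogen does not continue the earlier trend: going from ethyl to methyl gives a 5.3-fold higher number from compound 2 to compound 3 (0.72 log units; beyond the scatter), the opposite direction to the step that shortened the chain to ethyl. The longest and shortest chains shown do not separate, with a 1.5-fold higher number from compound 1 to compound 3 (0.18 log units; within the scatter), so compound 2 alone stands apart, and chain length here does not follow a steady one-way trend. Nothing available explains why one carbon changes the result in this way.

The compounds shown leave open how sharply this preference for ethyl is defined, since a propyl chain would show how compound 2 connects to the longer chain of compound 1. They also leave open how a branched isopropyl group, or a chain ending in an amine or a carboxylic acid, would read in this assay.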